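From a Benzyl to an Aryl Group on Sulfur

The compounds below may be only part of what the source reports. "The series", "measured", "known", "first", "only" and "open" are said of these compounds alone.

The measured compounds in a functional assay on DU-145 cells (Homo sapiens) for inhibition, read by trypan blue exclusion, with a stated time of 96 h; on this read-out higher numbers stand for weaker inhibition of growth and lower numbers for stronger inhibition of growth:
compound 1 `O=C(/C(=C\c1ccc(O)cc1O)Sc1ccc(Br)cc1)c1ccc(Cl)cc1` gives 50000 nM
compound 2 `COc1ccc(/C=C(/Sc2ccc(Br)cc2)C(=O)c2ccc(Cl)cc2)cc1` gives 50000 nM
compound 3 `COc1ccccc1/C=C(/SCc1ccc(F)cc1)C(=O)c1ccc(Cl)cc1` gives 10000 nM

Compound 3 stands lowest of the three numbers, a gap to both compound 1 and compound 2 that lies beyond the scatter. Going by the values given here, the only measured step, no change at the digits printed from compound 1 to compound 2 (within the scatter), changes the aryl group on the double-bonded chain carbon and stays within the scatter; it does not touch the sulfur substituent.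

Compound 4 `COc1ccccc1/C=C(/Sc1ccc(Br)cc1)C(=O)c1ccc(Cl)cc1` differs from compound 3 in one place: 4-bromophenyl in place of 4-fluorobenzyl on a sulfur. Among the compounds with values here, no measured step covers this exchange directly. What the data do show is that compound 1 and compound 2, both carrying 4-bromophenyl on sulfur, sit at the same high number, whereas compound 3, with 4-fluorobenzyl there, sits lower; compound 3 also differs from them in the other aryl group, so the two changes cannot be separated.

The expectation for compound 4 is therefore a step toward weaker inhibition of growth, a 3.0-fold higher number from compound 3 to compound 4 (0.48 log units; beyond the scatter), beyond the scatter but uncertain in size. Compound 4 is estimated at 30000 nM, in a range from 10000 nM to 60000 nM.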

Compound 4, concentration for 50% growth inhibition: 10000 nM
Compound 4: the middle estimate sits 3.0-fold (0.48 log units) above what was measured, within the range that was stated.
By their numbers in this assay, from the lowest: compounds 3 and 4 (each within the scatter of the next); then compounds 1 and 2 (each within the scatter of the next).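

On the sulfur, 4-bromophenyl can stand in place of 4-fluorobenzyl without a change that can be told apart in this assay (no change at the digits printed from compound 3 to compound 4 (within the scatter)), so this exchange alone does not move the number. With 4-bromophenyl held on the sulfur, the difference appears at the double-bonded chain carbon instead, where 2-methoxyphenyl replaces 4-methoxyphenyl (a 5.0-fold lower number from compound 2 to compound 4 (0.70 log units; beyond the scatter)) and also replaces 2,4-dihydroxyphenyl (a 5.0-fold lower number from compound 1 to compound 4 (0.70 log units; beyond the scatter)). No measurement is at hand that explains these results.

The compounds shown leave open how an amine, a carboxylic acid or a longer chain on the sulfur would read in place of these aryl-bearing groups. They also leave open whether a 2-ethoxyphenyl group on the double-bonded chain carbon would give a number like that of 2-methoxyphenyl.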